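A few compounds are considered here, and "the series" means these few. Any claim that something is new, unique, unknown or untested is made for them only; others in the source may bear on it.

Measured compounds in an assay on HL-60 cells for agonist activity at vitamin D3 receptor (Homo sapiens), read by microscopy, with a stated time of 96 h; a higher number here means that more compound is needed for the effect, a lower number that less compound is needed:
- compound 1 `C=CCN(C)C(=O)c1ccc(C(CC)(CC)c2ccc(OCC(O)C(C)(C)C)c(C)c2)n1CC`: 3950 nM
- compound 2 `CCn1c(C(=O)OCc2ccccn2)ccc1C(CC)(CC)c1ccc(OCC(O)C(C)(C)C)c(C)c1`: > 50000 nM

Compound 2 stands at the limit of this assay, not at a number; the value of compound 2 in this assay is a limit, as noted in the limit of > 50000 nM in this assay, at which 1 of the 2 values shown sits. Within the data shown here, the one measured step, an at least 12-fold higher number from compound 1 to compound 2 (1.10 log units; beyond the scatter), concerns the exchange of an amide for an ester on the carbonyl carbon and is beyond the scatter.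

Compound 3 `CCn1c(C(=O)OCc2ccc(F)cc2)ccc1C(CC)(CC)c1ccc(OCC(O)C(C)(C)C)c(C)c1` differs from compound 2 by 4-fluorophenyl in place of pyridin-2-yl on a saturated chain carbon bound to an oxygen next to a carbonyl group. Among the measured compounds shown here, no measured step concerns this exchange of an aromatic ring within the ester part; the step from compound 1 to compound 2 bears only on the carbonyl substituent and not on the ring. With compound 2 already at the limit of this assay, the expected step of a number no higher from compound 2 to compound 3 (the limit leaves the size open) is none beyond the scatter, and compound 3 is expected to sit at or near the same limit. For compound 3 the estimate in this assay is 50000 nM, with a range from 15000 nM to 150000 nM.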

Compound 3, half-maximal effective concentration: > 50000 nM
Compound 3: only a limit was reported; the forecaster's own chance of this, stated with the estimate: 70%; the middle value lies on the limit itself.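

In this assay compound 3 gives > 50000 nM, which is a limit of the assay. Placing (4-fluorobenzyl)oxy instead of allyl(methyl)amino on the carbonyl carbon gives an at least 12-fold higher number from compound 1 to compound 3 (1.10 log units; beyond the scatter), so the large step away from the amide of compound 1 is now seen for two esters, one carrying pyridin-2-yl and one carrying 4-fluorophenyl. The step between the two esters cannot be read, and no order of the two rings can be drawn: the limit of > 50000 nM in this assay, at which 2 of the 3 values shown sit.

As far as these compounds go, how far either ester lies past the limit stays open, and with it any effect of the ring exchange in the ester part. Also open, from the compounds shown here alone, is whether a carboxylic acid or a secondary amide on this carbonyl carbon would stay close to compound 1 or fall to the same limit.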